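This account rests on a few compounds, and the source may have more. Where it says the series, first, only, none or still open, it means among the compounds named here.

Measured compounds:
compound 1 `CN(c1ccccc1CCCn1nnnc1[C@@H](COCc1ccccc1)NC(=O)C(C)(C)N)S(C)(=O)=O`, 14 nM
compound 2 `CC(C)(N)C(=O)N[C@H](COCc1ccccc1)c1nnn(Cc2ccccc2)n1`, 1120 nM

Both were tested in a functional assay on H4 cells for agonist activity at growth hormone secretagogue receptor type 1 (Homo sapiens), read by FLIPR; a lower number here means that less compound is needed, a higher number that more compound is needed for the effect. Among the compounds with values here, compound 1 stands at the lowest of the two numbers, with 14 nM, and compound 2 gives 1120 nM, a gap that lies beyond the scatter; no single step links these two structures, so only the two values themselves can be compared.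

Compound 3 `CCCCNC(=O)CCCn1nnnc1[C@@H](COCc1ccccc1)NC(=O)C(C)(C)N` has not yet been measured. It differs from compound 1 by butylcarbamoyl in place of 2-(methyl(methylsulfonyl)amino)phenyl on a saturated chain carbon, three bonds along the chain from an aromatic nitrogen. Within the data shown here, no step between measured compounds mirrors this change, so the direction is uncertain; the aromatic ring and the sulfonyl group are lost and an open butyl amide arrives. Compound 3 is expected to give a higher number than compound 1, a step of a 7.1-fold higher number from compound 1 to compound 3 (0.85 log units; beyond the scatter), beyond the scatter. The estimate for compound 3 is 100 nM, within a range of 20 nM to 600 nM.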

Compound 3, half-maximal effective concentration: 30 nM
Beside the measured number, compound 3's estimate is 3.3-fold (0.52 log units) above it; the range from low to high includes it.
By their numbers in this assay, from the lowest: compound 1; then compound 3; then compound 2.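

Replacing 2-(methyl(methylsulfonyl)amino)phenyl with butylcarbamoyl on a saturated chain carbon, three bonds along the chain from an aromatic nitrogen, gives a 2.1-fold higher number from compound 1 to compound 3 (0.33 log units; beyond the scatter) in this assay, a modest step that lies just beyond the scatter. At this position, then, the six-membered aromatic ring and the sulfonyl group can both leave at only a modest cost, and an open chain with no ring takes their place, so neither is needed for a number of this order. Nothing measured here explains why the step is this small.

From the compounds shown here alone, the amide and the butyl chain arrive together in this one step, so what each contributes stays open. Also open, going by these compounds, is whether a carboxylic acid, an amine or a shorter chain at this place would hold the number.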